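The compounds below may be only part of what the source reports. "The series", "measured", "known", "first", "only" and "open" are said of these compounds alone.

Measured so far:
Compound 1, `O=C(NCc1ccc(C(=O)N2CCCCc3ccccc32)c(Cl)c1)Nc1c(F)cccc1F`: 40 nM in a functional assay on HEK293 cells for agonist activity at Vasopressin V2 receptor (Homo sapiens), read by a luciferase reporter and cAMP accumulation; a higher number here means that more compound is needed for the effect, a lower number that less compound is needed
Compound 2, `Cc1cc(C(=O)N2CCCCc3ccccc32)cc(C)c1CNC(=O)Nc1c(F)cccc1F`: 82 nM in this assay
Compound 3, `Cc1cc(C(=O)N2CCCCc3ccccc32)ccc1CNC(=O)Nc1ccccc1`: 130 nM in this assay

Among these three, compound 3 holds the highest number. Its nearest neighbour is compound 2, whose number is lower by an amount that stays within the scatter, so the two cannot be ordered. Compound 1 stands further off, with a number low enough to count as a real difference from compound 3.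

The next compound, compound 4, `Cc1cc(C(=O)N2CCCCc3ccccc32)ccc1CNC(=O)NCC(=O)OC(C)C`, is not yet measured. It departs from compound 3 by a single change: (isopropoxycarbonyl)methyl in place of phenyl on an amide-type nitrogen. Going by the values given here, every measured compound so far carries a ring at that position, so the series gives no direct guide to what an open chain there does. Without a comparable step among the measured compounds, the expectation must be cautious. Compound 4 is estimated to need more compound than compound 3, with the step from compound 3 to compound 4 expected to be a 3.5-fold higher number from compound 3 to compound 4 (0.54 log units; beyond the scatter), a movement beyond the scatter but of uncertain size. Compound 4 is therefore expected to give about 450 nM in this assay, with a plausible range from 120 nM to 2500 nM.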

Compound 4, half-maximal effective concentration: 140 nM
Compound 4: the middle estimate sits 3.2-fold (0.51 log units) above what was measured, and the stated range covers the measured number.
By their numbers in this assay, from the lowest: compound 1; then compounds 2, 3 and 4 (each within the scatter of the next).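

In this assay the exchange of phenyl for (isopropoxycarbonyl)methyl on the amide-type nitrogen comes to a 1.1-fold higher number from compound 3 to compound 4 (0.03 log units; within the scatter) and so leaves the two compounds indistinguishable. Until now every compound shown carried an aromatic ring at this position, and this single pair shows that such a ring is not required for agonist activity on the core of compound 3: an open chain with hydrogen-bond acceptors, which phenyl lacks, serves equally well in this comparison. Nothing measured here accounts for the two groups reading alike.

From the compounds shown here alone, what the chain contributes remains open, since a single step cannot separate the isopropyl ester from the chain that carries it, and a carboxylic acid, a primary amine or a longer alkyl chain on the same nitrogen could each give a different answer. Going by these compounds, it is also open whether (isopropoxycarbonyl)methyl would read the same way on the cores of compound 1 and compound 2, which differ from compound 3 in more than one place.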